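The source may hold more compounds than are shown below. What is called first, only, known or untested is meant among the compounds shown, and "the series" means these compounds.

Compound 1 `O=C1c2ccccc2CN1C1CCN(CC(O)COc2cccc(C(F)(F)F)c2)CC1`: 1200 nM
Compound 2 `COc1ccc(OCC(O)CN2CCC(N3Cc4ccccc4C3=O)CC2)cc1`: 2700 nM
Compound 3 `O=C1c2ccccc2CN1C1CCN(CC(O)COc2ccc(C(F)(F)F)cc2)CC1`: 1800 nM

Of the compounds shown here, three sharing one core have been tested in an assay on isolated protein for inhibition of sodium channel protein type 1 subunit alpha (Homo sapiens), read by patch clamp; a lower number here means a stronger inhibitor, a higher number a weaker inhibitor. Compound 1 gives 1200 nM, compound 2 gives 2700 nM, and compound 3 gives 1800 nM. For the measured compounds named here, compound 3 stands second highest of the three numbers; its step from compound 1 lies within the scatter, a 1.5-fold higher number from compound 1 to compound 3 (0.18 log units; within the scatter), as does the one from compound 2, a 1.5-fold lower number from compound 2 to compound 3 (0.18 log units; within the scatter). Going by the values given here, the only step beyond the scatter is a 2.3-fold higher number from compound 1 to compound 2 (0.35 log units; beyond the scatter), in which 4-methoxyphenyl replaces 3-(trifluoromethyl)phenyl on an oxygen on a saturated carbon.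

Compound 4 `COc1cccc(OCC(O)CN2CCC(N3Cc4ccccc4C3=O)CC2)c1` has not yet been measured. It differs from compound 3 in one place: 3-methoxyphenyl in place of 4-(trifluoromethyl)phenyl on an oxygen on a saturated carbon. Among the compounds with values here, two measured steps bear on this. The exchange of trifluoromethyl for methoxy on an aromatic carbon, a 1.5-fold lower number from compound 2 to compound 3 (0.18 log units; within the scatter), stayed within the scatter, while the exchange that also moved the group around the ring, a 2.3-fold higher number from compound 1 to compound 2 (0.35 log units; beyond the scatter), was modest. In this assay compound 4 is therefore expected to show a small rise, a 1.4-fold higher number from compound 3 to compound 4 (0.16 log units; within the scatter), though one that may fall within the scatter. The estimated value of compound 4 is 2600 nM, within a range from 1300 nM to 5200 nM.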

Compound 4, half-maximal inhibitory concentration: 3000 nM
The estimate for compound 4 lay 1.2-fold (0.06 log units) below the measured number; the range from low to high includes it.
By their numbers in this assay, from the lowest: compounds 1, 3, 2 and 4 (each within the scatter of the next, the first and the last beyond it).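

In this assay, 3-methoxyphenyl in place of 4-methoxyphenyl on the oxygen gives a 1.1-fold higher number from compound 2 to compound 4 (0.05 log units; within the scatter), so the two methoxyphenyl groups cannot be told apart here, and 3-methoxyphenyl in place of 4-(trifluoromethyl)phenyl gives a 1.7-fold higher number from compound 3 to compound 4 (0.22 log units; within the scatter). For the compounds shown here, the one new step beyond the scatter, and still a modest one, is methoxy in place of trifluoromethyl on an aromatic carbon, which gives a 2.5-fold higher number from compound 1 to compound 4 (0.40 log units; beyond the scatter). The exchange between trifluoromethyl and methoxy has now been seen twice, and the two readings agree: the same change on two cores in this assay, a 1.5-fold lower number (0.18 log units; within the scatter) from compound 2 to compound 3 and a 2.5-fold lower number (0.40 log units; beyond the scatter) from compound 4 to compound 1, 1.7-fold (0.22 log units) apart, within the scatter of two such steps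

The compounds shown leave open how a plain phenyl, or a phenyl carrying a chlorine, a nitrile or a dimethylamino group, would read in this assay. They also leave open what a longer chain in place of the hydroxyl-bearing chain, or a change elsewhere on the shared core, would do to these numbers.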